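The compounds below may be only part of what the source reports. "The series", "measured", "known", "first", "only" and "open" are said of these compounds alone.

Going by the values given here, compound 3 `O=C1N(Cc2ccccc2Br)c2cccn2S(=O)(=O)N1Cc1cccc(F)c1` is one of three compounds measured in an ADME assay on MT4 cells (Homo sapiens) for cytotoxicity, read by MTT assay, with a stated time of 5 days (a higher number here means that more compound is tolerated, a lower number that less compound is tolerated), and none of the three gave a number. In this assay compound 3 gives > 269000 nM, which is a limit of the assay and not a measured value. Compound 1 `N#Cc1ccccc1CN1C(=O)N(Cc2cccc(F)c2)S(=O)(=O)n2cccc21` gives > 305000 nM in this assay, again a limit. Compound 2 `O=C1N(Cc2ccc(Cl)cc2Cl)c2cccn2S(=O)(=O)N1Cc1cccc(Cl)c1` gives > 251000 nM in this assay, also a limit. Among the compounds with values here, the single step between measured compounds, a step that the two limits leave unreadable from compound 1 to compound 3, therefore has no readable size, since both ends sit at a limit of > 305000 nM in this assay, at which 1 of the 3 values shown sits (the limit of > 269000 nM in this assay, at which 1 of the 3 values shown sits).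

Compound 4 `O=C1N(Cc2ccc(Cl)cc2Cl)c2cccn2S(=O)(=O)N1Cc1cccc(F)c1` differs from compound 3 by 2,4-dichlorophenyl in place of 2-bromophenyl on a saturated chain carbon bound to an amide-type nitrogen in a ring. Within the data shown here, no measured step bears directly on this change. What the data do show is that compound 2, which carries the same 2,4-dichlorobenzyl group, also reached only a limit (the limit of > 251000 nM in this assay, at which 1 of the 3 values shown sits), and so did compound 3 with its 2-bromobenzyl group.

With every value shown sitting at a limit, no direction can be expected for the step that the limit leaves unreadable from compound 3 to compound 4, and compound 4 is estimated to show tolerance at or near the limit of this assay, around 270000 nM, within a range from 150000 nM to 450000 nM.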

Compound 4, half-maximal cytotoxic concentration: > 249000 nM
Compound 4 was reported as a limit; the forecaster's own chance of this, stated with the estimate: 85%; the middle value does not contradict the limit.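

Compound 4, like compounds 1, 2 and 3, reached only a limit in this assay, so the steps from compounds 1, 2 and 3 to compound 4 cannot be read. The compounds shown leave open at what concentration each one becomes toxic to the cells, and whether the changes among them shift that concentration at all.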